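Reconnecting the side chain of compound 3 as a secondary amide

A few compounds are considered here, and "the series" means these few. Any claim that something is new, unique, unknown or untested is made for them only; others in the source may bear on it.

Measured in a functional assay on MIA PaCa-2 cells (Homo sapiens) for inhibition, read by MTT assay, with a stated time of 7 days; on this read-out lower numbers stand for stronger inhibition and higher numbers for weaker inhibition:
- compound 1 `CCN(CC)S(=O)(=O)c1ccc(S(=O)(=O)N2CCC[C@@H](C(=O)NC3COC3)C2)cc1`: 2340 nM
- compound 2 `CCN(CC)S(=O)(=O)c1ccc(S(=O)(=O)N2CCC[C@@H](C(=O)N3CCC(C(F)(F)F)CC3)C2)cc1`: 320 nM
- compound 3 `CCN(CC)S(=O)(=O)c1ccc(S(=O)(=O)N2CCC[C@@H](C(=O)N3CCC(COC)CC3)C2)cc1`: 250 nM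

Compound 3, at 250 nM, stands at the low end of these numbers together with compound 2, since a 1.3-fold lower number from compound 2 to compound 3 (0.11 log units; within the scatter) remains within the scatter. Compound 4 `CCN(CC)S(=O)(=O)c1ccc(S(=O)(=O)N2CCC[C@@H](C(=O)N[C@H]3CC[C@@H](OC)CC3)C2)cc1` keeps the core of compound 3 and the same atoms, joined differently: (4-methoxycyclohexyl)amino in place of 4-(methoxymethyl)piperidin-1-yl on a carbonyl carbon. In words, (4-methoxycyclohexyl)amino stands in place of 4-(methoxymethyl)piperidin-1-yl on a carbonyl carbon.

Within the data shown here, no measured step makes this exact change. The closest evidence comes from compound 1, which also carries a substituted amino group on the carbonyl carbon. The data show a 7.3-fold lower number from compound 1 to compound 2 (0.86 log units; beyond the scatter) and a 9.4-fold lower number from compound 1 to compound 3 (0.97 log units; beyond the scatter), so both piperidin-1-yl groups gave lower numbers than (oxetan-3-yl)amino. That is a single amino example, however, and its small oxetane ring differs from the larger carbon ring of compound 4. Only part of those steps is therefore expected to be reversed, pointing to a modest rise. The step expected in this assay is a 2.2-fold higher number from compound 3 to compound 4 (0.34 log units; beyond the scatter). Compound 4 is expected at 550 nM, with an estimated range of 170 nM to 1800 nM.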

Compound 4, half-maximal inhibitory concentration: 960 nM
Estimate against measurement, compound 4: 1.7-fold (0.24 log units) below, and the stated range covers the measured number.
By their numbers in this assay, from the lowest: compounds 3 and 2 (each within the scatter of the next); then compound 4; then compound 1.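

In this assay, rejoining the same atoms as (4-methoxycyclohexyl)amino on the carbonyl carbon does not hold the level of the piperidin-1-yl amides (a 3.8-fold higher number from compound 3 to compound 4 (0.58 log units; beyond the scatter)), and the comparison with the trifluoromethyl-bearing amide points the same way (a 3.0-fold higher number from compound 2 to compound 4 (0.48 log units; beyond the scatter)). Having a secondary amide does not by itself set the number at this position, since the two amino groups also differ from each other, with 4-methoxycyclohexyl giving the lower number on the amide-type nitrogen (a 2.4-fold lower number from compound 1 to compound 4 (0.39 log units; beyond the scatter)). The position therefore responds both to how the atoms are joined and to what the amide nitrogen carries, though nothing given here explains either effect.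

The change from compound 3 to compound 4 alters the ring atoms, the amide hydrogen and the place of the methoxy group together, so the compounds shown cannot separate their contributions. Going by these compounds, a methyl group on the amide nitrogen of compound 4, or a 4-methoxypiperidin-1-yl group on the carbonyl carbon, would address parts of that question, and the other stereoisomer of the 4-methoxycyclohexyl group remains open as well.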